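Removing One Amino Acid Ester from a Floxuridine Prodrug

The compounds below may be only part of what the source reports. "The series", "measured", "known", "first", "only" and "open" are said of these compounds alone.

Compound 1 `N[C@@H](CCC(=O)OC[C@H]1O[C@@H](n2cc(F)c(=O)[nH]c2=O)C[C@@H]1OC(=O)CC[C@H](N)C(=O)O)C(=O)O`: 2650000 nM
Compound 2 `N[C@@H](CC(=O)OC[C@H]1O[C@@H](n2cc(F)c(=O)[nH]c2=O)C[C@@H]1OC(=O)C[C@H](N)C(=O)O)C(=O)O`: 2980000 nM

In an assay on cells (Oocyte) for inhibition of sodium- and chloride-dependent neutral and basic amino acid transporter B(0+) (Homo sapiens), read by LC-MS, with a stated time of 10 min (on this read-out lower numbers stand for stronger inhibition and higher numbers for weaker inhibition), compound 1 gives 2650000 nM, and compound 2 gives 2980000 nM; the two numbers lie within the scatter of each other, so neither stands apart. Compound 3 `N[C@@H](CCC(=O)O[C@H]1C[C@H](n2cc(F)c(=O)[nH]c2=O)O[C@@H]1CO)C(=O)O` differs from compound 1 by hydrogen in place of (3-amino-3-carboxypropyl)carbonyl on an oxygen on a saturated carbon, leaving a free hydroxymethyl on the shared core. Going by the values given here, no step between measured compounds is available to anchor this change. For compound 3 the step of a 1.1-fold lower number from compound 1 to compound 3 (0.03 log units; within the scatter) is expected to stay within the scatter, in no clear direction. Compound 3 is estimated at 2500000 nM, with a range from 800000 nM to 8000000 nM.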

Compound 3, half-maximal inhibitory concentration: 1840000 nM
Estimate against measurement, compound 3: 1.4-fold (0.13 log units) above, within the range that was stated.
By their numbers in this assay, from the lowest: compounds 3, 1 and 2 (each within the scatter of the next).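

In this assay, hydrogen in place of (3-amino-3-carboxypropyl)carbonyl on an oxygen on a saturated carbon gives a 1.4-fold lower number from compound 1 to compound 3 (0.16 log units; within the scatter). This single step shows that, with the other ester kept, this amino acid ester can be removed to leave a free hydroxymethyl without the read-out moving beyond the scatter. Nothing available accounts for this result. Going by these compounds, what stays open is whether a smaller acetyl group on this oxygen, or a chain longer than (3-amino-3-carboxypropyl)carbonyl, would read differently from compound 3.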